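Closing the side chain into a cyclobutane ring

This account rests on a few compounds, and the source may have more. Where it says the series, first, only, none or still open, it means among the compounds named here.

Compound 1 `CC(NC(=O)c1ccc(C#Cc2ccccc2)cc1)C(=O)NO` and compound 2 `NC[C@H](NC(=O)c1ccc(C#Cc2ccccc2)cc1)C(=O)NO` share a core and differ only on an amide-type nitrogen. In a physicochemical assay for solubility (a higher number here means a more soluble compound, a lower number a less soluble compound), compound 1 gives 29000 nM, while compound 2 gives 13000 nM, the lower of the two numbers; the step of a 2.2-fold lower number from compound 1 to compound 2 (0.35 log units; beyond the scatter) lies beyond the usual scatter. Compound 3 `O=C(NC1(C(=O)NO)CCC1)c1ccc(C#Cc2ccccc2)cc1` carries the change (a group of 8 heavy atoms (5 carbon, 1 nitrogen, 2 oxygen; one four-membered non-aromatic ring of carbon only) in place of a group of 7 heavy atoms (3 carbon, 2 nitrogen, 2 oxygen; no ring), on an amide-type nitrogen). That measured step concerns a different change, so it only loosely bears here; compound 3 is expected to land near the two known values, with the change a 1.4-fold higher number from compound 2 to compound 3 (0.14 log units; within the scatter) estimated. Compound 3 is therefore expected to show about 18000 nM, within a range from 6000 nM to 50000 nM.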

Compound 3, solubility: 5000 nM
For compound 3 the middle estimate is 3.6-fold (0.56 log units) above the measured one; the whole stated range lies above it.
By their numbers in this assay, from the lowest: compound 3; then compound 2; then compound 1.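

Closing the side chain into a ring gives the lowest number so far in this assay with 1-(hydroxycarbamoyl)cyclobutyl on the amide-type nitrogen. The ring compound sits clearly under both open-chain compounds, with a 2.6-fold lower number from compound 2 to compound 3 (0.41 log units; beyond the scatter) and a 5.8-fold lower number from compound 1 to compound 3 (0.76 log units; beyond the scatter) as the two steps. So this position responds to ring closure as well as to a change in the open chain, though nothing available here explains the drop. On these data alone, whether a larger ring such as cyclopentyl would go further remains open, as does the effect of an amine placed on the cyclobutane ring.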